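Pyrazolone amides: swapping the aryl group on ring nitrogen

This account rests on a few compounds, and the source may have more. Where it says the series, first, only, none or still open, it means among the compounds named here.

Cytotoxicity in this series is followed in a functional assay on HepG2 cells (Homo sapiens) for cytotoxicity, read by MTT assay, with a stated time of 72 h; on this read-out lower numbers stand for stronger inhibition and higher numbers for weaker inhibition. Compound 1 `Cc1cc(=O)n(-c2cccc(F)c2)nc1C(=O)Nc1ccc(Oc2ncnc3[nH]ccc23)c(F)c1` gives 23100 nM in this assay. Compound 2 `Cc1cc(=O)n(-c2ccccc2OC(F)(F)F)nc1C(=O)Nc1ccc(Oc2ncnc3c2ccn3C)c(F)c1` is reported in this assay only as the limit > 60000 nM, which is a limit of the measurement and not a number. Thus compound 2 stands at the limit of > 60000 nM in this assay, at which 1 of the 2 values shown sits, and of the two values shown only compound 1 carries a number. Going by the values given here, compound 1 and compound 2 differ in two places at once, so no single step is set between them; their values show one number and one limit.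

Compound 3 `Cc1cc(=O)n(-c2cccc(F)c2)nc1C(=O)Nc1ccc(Oc2ncnc3c2ccn3C)c(F)c1` remains to be measured. It arises from compound 2 by 3-fluorophenyl in place of 2-(trifluoromethoxy)phenyl on an aromatic nitrogen. Since compound 2 is known only as a limit, the step cannot be sized from the data. Given that compound 1, which carries the same 3-fluorophenyl group, gives 23100 nM, compound 3 is expected near 30000 nM in this assay, between 10000 nM and 90000 nM. This estimate implies a step of an at least 2.0-fold lower number from compound 2 to compound 3 (0.30 log units; that floor lies within the scatter), with a real chance that only a limit is returned again.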

Compound 3, half-maximal inhibitory concentration: > 60000 nM
Compound 3: only a limit was reported (the forecaster's own chance of this, stated with the estimate: 40%); at least 2.0-fold (0.30 log units) between middle value and limit.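

In this assay, methyl in place of hydrogen on an aromatic nitrogen of the core gives an at least 2.5-fold higher number from compound 1 to compound 3 (0.41 log units; beyond the scatter), so with the 3-fluorophenyl group held fixed, this single change shifts the read-out beyond the usual scatter, which compound 1 and compound 2 alone could not show. The 3-fluorophenyl group does not by itself bring a numerical value on the methyl-bearing core, as compound 3 also returns only a limit, which is not a number. The swap of 2-(trifluoromethoxy)phenyl for 3-fluorophenyl cannot be read, and the methyl-bearing compounds now both rest on the same limit: the limit of > 60000 nM in this assay, at which 2 of the 3 values shown sit.

As far as these compounds go, the true values of compound 2 and compound 3 stay open, and so does the size of the aryl swap on the methyl-bearing core. Also open, from the compounds shown here alone, is whether an amine or a carboxylic acid carried on that aromatic nitrogen in place of methyl, or a longer chain such as ethyl, would return a numerical value, and whether 2-(trifluoromethoxy)phenyl would read differently on the hydrogen-bearing core of compound 1.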